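This account rests on a few compounds, and the source may have more. Where it says the series, first, only, none or still open, it means among the compounds named here.

Values so far in a functional assay on K562 cells (Homo sapiens) for cytotoxicity, read by trypan blue exclusion, with a stated time of 96 h; a higher number here means a weaker inhibitor, a lower number a stronger inhibitor
compound 1 `COC(=O)CNc1cc(CS(=O)(=O)/C=C/c2c(OC)cc(OC)cc2OC)ccc1OC` gives 100 nM
compound 2 `COC(=O)C(F)(F)Nc1cc(CS(=O)(=O)/C=C/c2c(OC)cc(OC)cc2OC)ccc1OC` gives 250 nM
compound 3 `COC(=O)C(Nc1cc(CS(=O)(=O)/C=C/c2c(OC)cc(OC)cc2OC)ccc1OC)c1ccccc1` gives 30 nM

Compound 3 at 30 nM holds the lowest of the three numbers. Compound 4 `COC(=O)C(Nc1cc(CS(=O)(=O)/C=C/c2c(OC)cc(OC)cc2OC)ccc1OC)c1ccc(F)cc1` differs from it by fluoro in place of hydrogen on an aromatic carbon with fluoro in place of hydrogen on an aromatic carbon, para to a large group. Within the data shown here, no measured step alters that ring. Only indirect evidence bears on it: the modest 3.3-fold lower number from compound 1 to compound 3 (0.52 log units; beyond the scatter) on gaining the phenyl and the modest 2.5-fold higher number from compound 1 to compound 2 (0.40 log units; beyond the scatter) on gaining difluoro. Neither shows what a ring substituent does, so no step beyond the scatter is expected in this assay and no direction is favoured. The estimate means no change at the digits printed from compound 3 to compound 4 (within the scatter) as the expected step. Compound 4 is estimated at 30 nM with an expected range of 12 nM to 80 nM for this compound.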

Compound 4, half-maximal inhibitory concentration: 800 nM
For compound 4 the middle estimate is 27-fold (1.43 log units) below the measured one; measured number outside the range, above it.
By their numbers in this assay, from the lowest: compound 3; then compound 1; then compound 2; then compound 4.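

In this assay this ring position proves sensitive: fluoro in place of hydrogen on an aromatic carbon, para to a large group, gives a large loss (a 27-fold higher number from compound 3 to compound 4 (1.43 log units; beyond the scatter)). The benefit of phenyl does not carry over to 4-fluorophenyl (an 8.0-fold higher number from compound 1 to compound 4 (0.90 log units; beyond the scatter)), and compound 4 also falls behind the difluoro analogue (a 3.2-fold higher number from compound 2 to compound 4 (0.51 log units; beyond the scatter)). No available evidence bears on this loss. Still open, going by these compounds, is whether the loss is specific to fluoro or also extends to chloro, methoxy or hydroxy at this carbon.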